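This account rests on a few compounds, and the source may have more. Where it says the series, first, only, none or still open, it means among the compounds named here.

Measured so far in a functional assay on the whole organism with Mus musculus as the target; a lower number here means that less compound is needed, a higher number that more compound is needed for the effect:
- compound 1 `C/C(=C\C(=O)NC1CC1)c1cccc(F)c1`: 122 mg/kg
- compound 2 `CNC(=O)/C=C1\CCc2c(F)cc(F)cc21`: 45 mg/kg
- compound 3 `NC(=O)/C=C1\CCc2cc(F)cc(F)c21`: 44 mg/kg

Compound 2, at 45 mg/kg, lies within the scatter of compound 3, at 44 mg/kg. Both stand apart from compound 1, which at 122 mg/kg has a number beyond the scatter on the higher side.

The next compound, compound 4 `O=C(/C=C1\CCc2c(F)cc(F)cc21)NCCO`, has not yet been measured. It differs from compound 2 by hydroxymethyl in place of hydrogen on a saturated chain carbon bound to an amide-type nitrogen, with hydroxymethyl in place of hydrogen on a saturated chain carbon bound to an amide-type nitrogen. The same difference can be read as methylcarbamoyl to (2-hydroxyethyl)carbamoyl.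

Going by the values given here, no pair of measured compounds differs in only one place, so the data offer no direct guide to this change. A modest move towards a higher number is expected in this assay, and it may not clear the scatter by much. The estimated change is a 1.6-fold higher number from compound 2 to compound 4 (0.19 log units; within the scatter). For compound 4 the expected value is 70 mg/kg, with an estimated range of 30 mg/kg to 170 mg/kg.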

Compound 4, dose for half-maximal effect: 100 mg/kg
For compound 4 the middle estimate is 1.4-fold (0.15 log units) below the measured one; low and high end bracket the measured number.
By their numbers in this assay, from the lowest: compounds 3 and 2 (each within the scatter of the next); then compounds 4 and 1 (each within the scatter of the next).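

In this assay, going by these compounds alone, this is the first step that can be read at the amide substituent: hydroxymethyl in place of hydrogen on a saturated chain carbon bound to an amide-type nitrogen gives a 2.2-fold higher number from compound 2 to compound 4 (0.35 log units; beyond the scatter), a modest step but beyond the scatter. The chain carbon is therefore not indifferent to this change, and going from methyl to 2-hydroxyethyl means that more compound is needed for the effect. Nothing available gives a reason for the shift.

Whether the shift belongs to the hydroxyl or simply to the longer chain stays open, as neither an ethyl nor a 2-methoxyethyl group on the amide nitrogen is among the compounds shown. Also open, from the compounds shown here alone, is how an amine or a carboxylic acid at the end of this chain would read in this assay.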